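This account rests on a few compounds, and the source may have more. Where it says the series, first, only, none or still open, it means among the compounds named here.

In a functional assay on HL-60 cells (Homo sapiens) for cytotoxicity (on this read-out higher numbers stand for weaker inhibition and lower numbers for stronger inhibition), compound 1 `CC1(C)CCC(C)(C)c2cc(/C=C/c3ccc(N)cc3)ccc21` gives 18000 nM and compound 2 `COc1ccc(/C=C(\C)c2ccc3c(c2)C(C)(C)CCC3(C)C)cc1N` gives 20000 nM. These two values lie within the scatter of each other, so the numbers set no order between compound 2 and compound 1. Compound 3 `COc1ccc(/C=C(/C)c2ccc3c(c2)C(C)(C)CCC3(C)C)cc1N` has not yet been measured. It is related to compound 2 by a single change: the two compounds have the same atoms and bonds and differ only in configuration as drawn: 1 of 1 stereo elements differ; a double bond is drawn E in compound 2 and Z in compound 3. The two compounds have the same atoms and bonds, and a double bond is drawn E in compound 2 and Z in compound 3. Among the compounds with values here, no measured pair shows what such a change does in this assay, so no step beyond the scatter is expected in either direction. The estimated step is small, a 1.1-fold lower number from compound 2 to compound 3 (0.05 log units; within the scatter). For compound 3 the expected value is 18000 nM, within an estimated range of 7000 nM to 40000 nM.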

Compound 3, half-maximal inhibitory concentration: 42000 nM
For compound 3 the middle estimate is 2.3-fold (0.37 log units) below the measured one; the whole stated range lies below it.
By their numbers in this assay, from the lowest: compounds 1 and 2 (each within the scatter of the next); then compound 3.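

Within the data shown here, until now, no pair showed what the configuration of this double bond does in this assay; the new pair shows that it can shift the read-out, with a 2.1-fold higher number from compound 2 to compound 3 (0.32 log units; beyond the scatter). Of these two compounds, the one drawn E, compound 2, therefore inhibits more strongly than the one drawn Z, compound 3. The shift can be assigned to the double bond alone, because nothing else separates the two structures: the fact that compounds 2 and 3 differ only in the configuration as drawn

This remains a single pair, so the compounds shown do not tell whether the same change would have a similar effect on a different substitution pattern, for instance with a carboxylic acid in place of the amine. They also leave open how the double-bond configuration alters the read-out, since nothing shown reports the shape or binding of either compound.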